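Chloro step on the 2-phenylethenyl compound

This account rests on a few compounds, and the source may have more. Where it says the series, first, only, none or still open, it means among the compounds named here.

In a functional assay on Caco-2 cells (Homo sapiens) for inhibition, read by MTT assay, with a stated time of 48 h, tested at 10 uM (on this read-out lower numbers stand for less inhibition of growth and higher numbers for more inhibition of growth at the one concentration tested), compound 3 `CN1CC[C@H](c2c(O)cc(O)c3c(=O)cc(/C=C/c4ccccc4)oc23)[C@H](O)C1` gives 72% as the highest of three numbers. Compound 1 `Cc1oc2c([C@H]3CCN(C)C[C@H]3O)c(O)cc(O)c2c(=O)c1C(O)c1ccccc1Br` gives 7% and compound 2 `Cc1oc2c([C@H]3CCN(C)C[C@H]3O)c(O)cc(O)c2c(=O)c1C(O)c1ccc(F)cc1` gives 11%. The gaps from compound 3 to both of these lie beyond the scatter. Compound 4 `CN1CC[C@H](c2c(O)cc(O)c3c(=O)cc(/C=C/c4ccc(Cl)cc4)oc23)[C@H](O)C1` carries chloro in place of hydrogen on an aromatic carbon, para to a large group (chloro in place of hydrogen on an aromatic carbon), which reads as phenyl to 4-chlorophenyl. Within the data shown here, the only measured step, 4-fluorophenyl in place of 2-bromophenyl, is a number 4 percentage points higher from compound 1 to compound 2 (within the scatter) and lies within the scatter, but it sits on a different chain and bears only weakly here. Among the measured compounds shown here, no measured step touches the 2-phenylethenyl group, so the range stays wide and no change beyond the scatter is expected. The estimated step is a number 2 percentage points lower from compound 3 to compound 4 (within the scatter) on this evidence. In this assay compound 4 is expected at 70% (estimated range 45% to 90%).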

Compound 4, percent growth inhibition at one concentration: 70%
Estimate against measurement, compound 4: no gap at the digits printed; the measured number falls inside the stated range.
By their numbers in this assay, from the lowest: compounds 1 and 2 (each within the scatter of the next); then compounds 4 and 3 (each within the scatter of the next).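

In this assay, among these compounds, the step at this position is a number 2 percentage points lower from compound 3 to compound 4 (within the scatter), the first measured step on the 2-phenylethenyl group. The high reading of compound 3 therefore holds with chloro in place of hydrogen on this aromatic carbon, para to a large group. No measured information on the compounds accounts for this outcome.

The compounds shown leave open how an amine or a carboxylic acid at this same place would read in this assay. They also leave open whether a longer chain in place of the chloro would keep the reading of compound 4.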